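Swapping Methoxy for Methyl on the Amide Aryl Ring

The source may hold more compounds than are shown below. What is called first, only, known or untested is meant among the compounds shown, and "the series" means these compounds.

Compound 1 `COc1ccc(-n2nc(C(N)=O)nc2-c2cc(OC)c(OC)c(OC)c2)cc1` gives 64% in a functional assay on the whole organism for inhibition, with Rattus norvegicus as the target, read by paw edema, with stated times of 30 min and 5 h, at a dose of 0.28 mmol/kg by the oral route; on this read-out higher numbers stand for more inhibition at the one dose given (going by the name of the read-out) and lower numbers for less inhibition.
Compound 2 `CNC(=O)c1nc(-c2cc(OC)c(OC)c(OC)c2)n(-c2ccc(OC)cc2)n1` gives 50%.
Compound 3 `COc1ccc(NC(=O)c2nc(-c3cc(OC)c(OC)c(OC)c3)n(-c3ccc(OC)cc3)n2)cc1` gives 51%.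

In this assay compound 3 stands second highest of the three numbers: it lies within the scatter of compound 2, as a number 1 percentage points higher from compound 2 to compound 3 (within the scatter), and beyond the scatter below compound 1, as a number 13 percentage points lower from compound 1 to compound 3 (beyond the scatter). Compound 4 `COc1ccc(-n2nc(C(=O)Nc3ccc(C)cc3)nc2-c2cc(OC)c(OC)c(OC)c2)cc1` differs from compound 3 in one place: methyl in place of methoxy on an aromatic carbon. Within the data shown here, no measured step changes the ring that hangs on the amide nitrogen; the measured steps change what sits on that nitrogen itself, a number 14 percentage points lower from compound 1 to compound 2 (beyond the scatter), a number 13 percentage points lower from compound 1 to compound 3 (beyond the scatter) and a number 1 percentage points higher from compound 2 to compound 3 (within the scatter). The last of these shows that exchanging a methyl for a 4-methoxyphenyl there left the read-out unchanged. The step expected for no change at the digits printed from compound 3 to compound 4 (within the scatter) is therefore none beyond the scatter. Compound 4 is estimated to give 51%, between 40% and 62%.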

Compound 4, a percentage reported as inhibition, in the whole organism at one dose (the size of the read-out at that dose, not a potency): 42%
The estimate for compound 4 lay 9 percentage points above the measured number; measured number inside the range.
By their numbers in this assay, from the lowest: compounds 4, 2 and 3 (each within the scatter of the next); then compound 1.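

In this assay, methyl in place of methoxy on the ring carried by the amide nitrogen gives a number 9 percentage points lower from compound 3 to compound 4 (within the scatter) and so the two cannot be told apart at this position. The 4-methylphenyl amide likewise cannot be told apart from the methyl amide, with a number 8 percentage points lower from compound 2 to compound 4 (within the scatter) while a number 22 percentage points lower from compound 1 to compound 4 (beyond the scatter) shows that compound 1, with its free amide, stays apart from it. Nothing measured here explains these numbers. As far as these compounds go, whether an amine or a carboxylic acid on this ring would also leave the read-out within the scatter remains open.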